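A Second Methyl on the Sulfur-Containing Core

This account rests on a few compounds, and the source may have more. Where it says the series, first, only, none or still open, it means among the compounds named here.

Measured compounds in a functional assay on L1210 cells (Mus musculus) for antiproliferative activity, with a stated time of 48 h; a lower number here means a stronger inhibitor, a higher number a weaker inhibitor:
Compound 1, `CCOC(=O)Nc1cc2c(c(N)n1)N=C(c1ccccc1)CO2`, gives 0.225 uM.
Compound 2, `CCOC(=O)Nc1cc2c(c(N)n1)N=C(c1ccccc1)C(C)O2`, gives 0.11 uM.
Compound 3, `CCOC(=O)Nc1cc2c(c(N)n1)N=C(c1ccccc1)C(C)S2`, gives 1.6 uM.

Compounds 1 and 2 share a core and differ by methyl in place of hydrogen on a saturated ring carbon; this change gave a 2.0-fold lower number from compound 1 to compound 2 (0.31 log units; beyond the scatter). Compound 3 has a different core, and the difference between the two cores is not broken down here; its value is the highest of the three, well apart from both compound 1 and compound 2.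

Compound 4, `CCOC(=O)Nc1cc2c(c(N)n1)N=C(c1ccccc1)C(C)(C)S2`, is not yet measured. It differs from compound 3 by methyl in place of hydrogen on a saturated ring carbon. Within the data shown here, this is the same kind of change as the one from compound 1 to compound 2, but not the same: in compound 3 the ring holds 1 nitrogen and 1 sulfur and the carbon is next to the ring sulfur, whereas in compound 1 the ring holds 1 nitrogen and 1 oxygen and the carbon is next to the ring oxygen. Moreover compound 3 already bears one methyl on this saturated ring carbon, so the second methyl has no measured precedent.

The step from compound 3 to compound 4 in this assay is expected to be a 1.6-fold lower number from compound 3 to compound 4 (0.20 log units; within the scatter), resting on the earlier step of a 2.0-fold lower number from compound 1 to compound 2 (0.31 log units; beyond the scatter), tempered because compound 3 starts at 1.6 uM on a core where the first methyl's effect is unmeasured. Compound 4 is estimated at 1 uM, between 0.4 uM and 3 uM.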

Compound 4, concentration for 50% inhibition: > 10 uM
Compound 4 ended at the assay's limit; the forecaster's own chance of this, stated with the estimate: 5%; middle value at least 10-fold (1.00 log units) from the limit.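

In this assay compound 4 gives > 10 uM, which is a limit of the assay and not a number. Putting methyl in place of hydrogen on the saturated ring carbon next to the ring sulfur gave an at least 6.2-fold higher number from compound 3 to compound 4 (0.79 log units; beyond the scatter), so the small gain seen on the oxygen-containing core does not carry over to the sulfur-containing core, and the direction of the step reverses: the same change on two cores in this assay, a 2.0-fold lower number (0.31 log units; beyond the scatter) from compound 1 to compound 2 and an at least 6.2-fold higher number (0.79 log units; beyond the scatter) from compound 3 to compound 4, at least 12-fold (1.10 log units) apart, beyond the scatter of two such steps This does not show which difference between the two steps matters, since the ring of compound 3 holds sulfur rather than oxygen and its ring carbon already bears a methyl, and these two features change together here.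

The compounds shown leave open what a single methyl does on the sulfur-containing core, and what a second methyl would do on the core of compound 2. They also leave open how a larger group on this ring carbon, such as an ethyl or a longer chain, would behave on either core.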